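Aryl swap on the ring nitrogen: outlook for compound 3

The source may report more compounds than this note shows. Statements on the series, on what has been measured and on what is new or still open speak of the compounds shown alone.

Measured so far:
compound 1 `COc1ccccc1-n1cc(CN2C(=O)C[C@@H]3CC[C@@]2(C)C3(C)C)nn1` — 120 nM
compound 2 `CC1(C)[C@H]2CC[C@]1(C)N(Cc1cn(-c3cccc(F)c3)nn1)C(=O)C2` — 220 nM

In a functional assay on PANC-1 cells (Homo sapiens) for inhibition, read by MTT assay, with a stated time of 24 h (a lower number here means a stronger inhibitor, a higher number a weaker inhibitor), compound 2 gives 220 nM, the highest of the two numbers shown; nearest is compound 1, the step being a 1.8-fold higher number from compound 1 to compound 2 (0.26 log units; within the scatter). Compound 3 `CC1(C)[C@H]2CC[C@]1(C)N(Cc1cn(-c3ccc(Br)cc3)nn1)C(=O)C2` differs from compound 2 by 4-bromophenyl in place of 3-fluorophenyl on an aromatic nitrogen. Within the data shown here, the one step that bears on this, a 1.8-fold higher number from compound 1 to compound 2 (0.26 log units; within the scatter), also exchanged one aryl group for another on the same nitrogen and stayed within the scatter, so no step beyond the scatter is expected here either, a 1.1-fold higher number from compound 2 to compound 3 (0.06 log units; within the scatter). For compound 3 the estimate in this assay is 250 nM, expected between 100 nM and 600 nM.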

Compound 3, half-maximal inhibitory concentration: 200 nM
Estimate against measurement, compound 3: 1.3-fold (0.10 log units) above; the range from low to high includes it.
By their numbers in this assay, from the lowest: compounds 1, 3 and 2 (each within the scatter of the next).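

In this assay a third aryl group on this nitrogen again stays within the scatter, with a 1.1-fold lower number from compound 2 to compound 3 (0.04 log units; within the scatter) and a 1.7-fold higher number from compound 1 to compound 3 (0.22 log units; within the scatter). The 4-bromophenyl, 3-fluorophenyl and 2-methoxyphenyl compounds are therefore not separated at this position. Nothing available explains this flat result.

Open, on these data alone, is whether a phenyl bearing a carboxylic acid or an amine, or a longer chain in place of the aryl group, would move the number beyond the scatter. Changes to the shared core also remain open.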